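The compounds below may be only part of what the source reports. "The series", "measured", "known", "first", "only" and "open" are said of these compounds alone.

Three compounds have numbers in this series. Compound 1, `COc1cccc(N2CCN(C(=O)C3CN(S(=O)(=O)c4ccc(OC)c5ccccc45)c4ccccc43)CC2)c1`, gives 63.1 nM in a functional assay on CHO cells for antagonist activity at 5-hydroxytryptamine receptor 6 (Homo sapiens), read by FLIPR; on this read-out lower numbers stand for stronger inhibition and higher numbers for weaker inhibition. Compound 2, `CCN(CC)CCNC(=O)C1CN(S(=O)(=O)c2ccc(OC)c3ccccc23)c2ccccc21`, gives 20 nM in this assay. Compound 3, `CN1CCC(N(C)C(=O)C2CN(S(=O)(=O)C3=CC4CCOC4C=C3)c3ccccc32)CC1`, gives 31.6 nM in this assay, the second highest of the three numbers; its nearest neighbour is compound 2, whose number is lower by an amount within the scatter, and its furthest is compound 1, whose number is higher by an amount that also stays within the scatter. On these numbers, then, the three compounds cannot be told apart.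

Compound 4, `COc1cc(C)c(S(=O)(=O)N2CC(C(=O)N(C)C3CCN(C)CC3)c3ccccc32)c(C)c1C`, has not yet been measured. It differs from compound 3 on the sulfonyl sulfur, as follows: a group of 11 heavy atoms (10 carbon, 1 oxygen; one six-membered aromatic ring of carbon only) in place of a group of 9 heavy atoms (8 carbon, 1 oxygen; one five-membered non-aromatic ring with 1 hetero atom, one six-membered non-aromatic ring of carbon only), on a sulfonyl sulfur.

For the measured compounds named here, no measured pair in this set shows the effect of such a change on its own, so the direction cannot be read from data. Since every measured compound, with either of two different groups on the sulfonyl sulfur, sits within the scatter of the others, the step from compound 3 to compound 4 is expected to be small, a 1.1-fold lower number from compound 3 to compound 4 (0.05 log units; within the scatter), with no clear direction beyond the scatter.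

Compound 4 is therefore estimated at 28 nM in this assay, with a likely range from 9 nM to 90 nM.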

Compound 4, inhibition constant: 100 nM
Compound 4: middle estimate off by 3.6-fold (0.55 log units), on the low side, outside the stated range (above it).
By their numbers in this assay, from the lowest: compounds 2, 3, 1 and 4 (each within the scatter of the next, the first and the last beyond it).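

Placing the 4-methoxy-2,3,6-trimethylphenyl group on the sulfonyl sulfur, in place of the group with a five-membered non-aromatic ring and a six-membered non-aromatic ring of carbon only, gives a 3.2-fold higher number from compound 3 to compound 4 (0.50 log units; beyond the scatter) in this assay. For the compounds shown here, this is the first change that can be read on its own, since the rest of the molecule stays the same, and it shows that the number responds to what this position carries. The earlier compounds shown here could not show this, as they differ in more than one place and their numbers all lie within the scatter of one another. Nothing available here accounts for the step.

From the compounds shown here alone, a single step cannot separate the contribution of the aromatic ring from that of its methoxy and methyl groups, so it remains open whether a plain phenyl or a 4-methoxyphenyl group on the sulfonyl sulfur would stand nearer compound 3 or compound 4. Going by these compounds, it also remains open whether the same change would have a similar effect alongside the amide of compound 2.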